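The source may hold more compounds than are shown below. What is called first, only, known or untested is meant among the compounds shown, and "the series" means these compounds.

Measured compounds:
- compound 1, `Cc1ccc(OCC(=O)N(Cc2cccs2)C(C)(C)C)cc1`: 11000 nM
- compound 2, `Cc1ccc(OCC(=O)N(Cc2cccs2)c2nccn2C)cc1`: 1790 nM

Compound 2 holds the lowest of the two numbers in an assay on HEK293 cells for agonist activity at transient receptor potential cation channel subfamily M member 8 (Homo sapiens), read by fluorescence and calcium flux, with a stated time of 15 min; on this read-out higher numbers stand for an effect only at larger amounts of compound and lower numbers for an effect already at smaller amounts; its nearest neighbour is compound 1, which stands higher by a 6.1-fold lower number from compound 1 to compound 2 (0.79 log units; beyond the scatter). Compound 3, `CCCN(Cc1cccs1)C(=O)COc1ccc(C)cc1`, is not yet measured. It differs from compound 2 by propyl in place of 1-methyl-1H-imidazol-2-yl on an amide-type nitrogen. For the measured compounds named here, the only step that bears on this is the one in which an alkyl group on that nitrogen was replaced by the imidazolyl group, a 6.1-fold lower number from compound 1 to compound 2 (0.79 log units; beyond the scatter); compound 3 reverses that kind of change, so the number is expected to rise. For compound 3 the estimate is 7000 nM, from 2500 nM to 20000 nM, an expected step of a 3.9-fold higher number from compound 2 to compound 3 (0.59 log units; beyond the scatter).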

Compound 3, half-maximal effective concentration: 40 nM
Beside the measured number, compound 3's estimate is 180-fold (2.24 log units) above it, outside the stated range (below it).
By their numbers in this assay, from the lowest: compound 3; then compound 2; then compound 1.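

In this assay the 1-methyl-1H-imidazol-2-yl group proves not to be what gives a low number on the amide-type nitrogen, since propyl in its place gives a far lower one (a 45-fold lower number from compound 2 to compound 3 (1.65 log units; beyond the scatter)). Alkyl groups at this place also differ widely among themselves, as propyl in place of tert-butyl shows (a 280-fold lower number from compound 1 to compound 3 (2.44 log units; beyond the scatter)), so tert-butyl does not speak for alkyl groups in general. Nothing at hand explains why these groups differ so much. Going by these compounds, whether ethyl, isopropyl or a longer chain such as butyl would stand nearer propyl or tert-butyl stays open.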